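Methoxy placement on the dienone arms and cell growth inhibition

The source may hold more compounds than are shown below. What is called first, only, known or untested is meant among the compounds shown, and "the series" means these compounds.

Compound 1 `COc1ccccc1/C=C1\CCC/C(=C\c2cccc(OC)c2OC)C1=O` and compound 2 `COc1cccc(/C=C2\CCC/C(=C\c3cccc(OC)c3OC)C2=O)c1` share one core and differ only by 3-methoxyphenyl in place of 2-methoxyphenyl on a double-bonded chain carbon bound to a double-bonded ring carbon. In a functional assay on MCF7 cells (Homo sapiens) for cytotoxicity, read by MTT assay, with a stated time of 72 h (on this read-out higher numbers stand for weaker inhibition and lower numbers for stronger inhibition), compound 1 gives 12000 nM, while compound 2 gives 5900 nM, which is a 2.0-fold lower number from compound 1 to compound 2 (0.31 log units; beyond the scatter). Compound 3 `COc1ccc(/C=C2\CCC/C(=C\c3cccc(OC)c3OC)C2=O)c(OC)c1` carries, relative to compound 1, the change (methoxy in place of hydrogen on an aromatic carbon). In this assay compound 3 reaches only the limit of the assay, > 20000 nM, a limit and not a number (the limit of > 20000 nM in this assay, at which 1 of the 3 values shown sits). That gives an at least 1.6-fold higher number from compound 1 to compound 3 (0.22 log units; that floor lies within the scatter). Compound 4 `COc1cc(/C=C2\CCC/C(=C\c3cccc(OC)c3OC)C2=O)cc(OC)c1` is not yet measured; relative to compound 2 it carries methoxy in place of hydrogen on an aromatic carbon, the same kind of change as from compound 1 to compound 3, though the entering methoxy now sits meta to a large group rather than para to a large group. Compound 4 is expected to show a 2.0-fold higher number from compound 2 to compound 4 (0.31 log units; beyond the scatter) in this assay, resting on the weakening seen for compound 3 in an at least 1.6-fold higher number from compound 1 to compound 3 (0.22 log units; that floor lies within the scatter). Compound 4 is therefore estimated at 12000 nM, between 4000 nM and 40000 nM.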

Compound 4, half-maximal inhibitory concentration: 1700 nM
The estimate for compound 4 lay 7.1-fold (0.85 log units) above the measured number; measured number outside the range, below it.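

Placed on the core of compound 2, the methoxy gives a 3.5-fold lower number from compound 2 to compound 4 (0.54 log units; beyond the scatter) in this assay, so the weakening seen on the core of compound 1 did not carry over, and the two steps differ: the same change on two cores in this assay, an at least 1.6-fold higher number (0.22 log units; that floor lies within the scatter) from compound 1 to compound 3 and a 3.5-fold lower number (0.54 log units; beyond the scatter) from compound 2 to compound 4, at least 5.7-fold (0.76 log units) apart, beyond the scatter of two such steps
Compound 3 gives > 20000 nM in this assay, a limit of the assay and not a number: the limit of > 20000 nM in this assay, at which 1 of the 4 values shown sits.
These two pairs show that this change cannot be assumed to act alike on both cores, but they give no general rule and no reason, and the entering methoxy also sits at a different place on the ring in each pair, so core and placement cannot be told apart.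

The compounds shown leave open whether a hydroxyl group, an ethoxy group or an amine at the place taken by the new methoxy in compound 4 would follow the same course. They also leave open whether the lower number for compound 4 holds on other cell types.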